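A few compounds are considered here, and "the series" means these few. Any claim that something is new, unique, unknown or untested is made for them only; others in the source may bear on it.

Three compounds of this series have been run in a functional assay on the whole organism (blood, strain albino) with Mus musculus as the target, with stated times of 6 days and 4 h, at a dose of 0.4 mmol/kg by the oral route; a higher number here means more inhibition at the dose given (going by the name of the read-out), a lower number less inhibition. Compound 1 `Cc1cc(C(=O)O)nn1-c1ccc(S(=O)(=O)NC(=S)NC2CCCCC2)cc1` gives 1%, compound 2 `Cc1cc(C(=O)O)nn1-c1ccc(S(=O)(=O)NC(=O)NCc2ccccc2)cc1` gives 0%, and compound 3 `Cc1cc(C)n(-c2ccc(S(=O)(=O)NC(=O)NC3CCCCC3)cc2)n1` gives 10%. Compound 3 stands within the scatter of both other numbers: its nearest neighbour is compound 1 and its furthest is compound 2, and neither gap is beyond the usual scatter, so no ranking of the three can be drawn.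

Compound 4 `Cc1cc(C(=O)O)nn1-c1ccc(S(=O)(=O)NC(=O)NC2CCCCC2)cc1` has not yet been measured in this assay. It differs from compound 3 in one place: carboxy in place of methyl on an aromatic carbon. Compound 1 and compound 2 already carry the carboxy group on the shared core, and compound 1 with 1% and compound 2 with 0% both sit at the low end of the scale. Within the data shown here, no step between measured compounds is available for this change on its own, so the expectation rests on those two numbers and on the value of compound 3. The step expected from compound 3 to compound 4 is a number 6 percentage points lower from compound 3 to compound 4 (within the scatter), which is none beyond the scatter in either direction. For compound 4 the estimate in this assay is 4%, with a range from 0% to 15%.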

Compound 4, a percentage reported as inhibition, in the whole organism at one dose (the size of the read-out at that dose, not a potency): 1%
For compound 4 the middle estimate is 3 percentage points above the measured one; the measured number falls inside the stated range.
By their numbers in this assay, from the lowest: compounds 2, 1, 4 and 3 (each within the scatter of the next).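

Carboxy in place of methyl on an aromatic carbon of the five-membered aromatic ring now has a reading as a single change in this assay, and the step is a number 9 percentage points lower from compound 3 to compound 4 (within the scatter) for the change from 3,5-dimethyl-1H-pyrazol-1-yl to 3-carboxy-5-methyl-1H-pyrazol-1-yl. With the carboxy group held in place, compound 4 also gives two further single-change readings: cyclohexyl in place of benzyl on an amide-type nitrogen gives a number 1 percentage points higher from compound 2 to compound 4 (within the scatter) and the oxygen-bearing group in place of the sulfur-bearing group on the sulfonamide nitrogen gives no change at the digits printed from compound 1 to compound 4 (within the scatter) in this series. All three steps stay inside the scatter, so at this one oral dose neither this position nor the two changes elsewhere in the molecule separates any pair of compounds, and no effect can be assigned to the carboxy group, the cyclohexyl group or the sulfur-for-oxygen exchange.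

As far as these compounds go, whether a methyl ester, a primary amide or an aminomethyl group on the same aromatic carbon would read apart from carboxy and methyl remains open, as does the reading of a longer chain such as propyl there. Nothing available bears on what lies behind these steps.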